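Cytotoxicity on PC-3 cells: an oxadiazole in place of methyl

This account rests on a few compounds, and the source may have more. Where it says the series, first, only, none or still open, it means among the compounds named here.

The series is measured in an ADME assay on PC-3 cells (Homo sapiens) for cytotoxicity, read by WST assay, tested at 100 uM; on this read-out higher numbers stand for more inhibition at the one concentration tested (going by the name of the read-out) and lower numbers for less inhibition. Compound 2 `Cc1cccc(C(=O)N2CCCC(C(=O)Nc3ccc(Cl)cc3)C2)c1` gives 0% in this assay, so no inhibition of the cells is seen at the single concentration tested. Among the compounds with values here, compound 1 `O=C(Nc1cccc(N2CCCC2=O)c1)C1CCCN(C(=O)c2cc(C(F)(F)F)cc(C(F)(F)F)c2)C1` gives 0%, and compound 3 `O=C(Nc1cccc(Oc2ccccn2)c1)C1CCCN(C(=O)c2cc(C(F)(F)F)cc(C(F)(F)F)c2)C1` gives 0%; the one step between measured compounds, no change at the digits printed from compound 1 to compound 3 (within the scatter), shows that swapping one aromatic substituent for another left the read-out where it was. Compound 2 therefore stands level with compounds 1 and 3.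

Compound 4 `Cc1nc(-c2cccc(C(=O)N3CCCC(C(=O)Nc4ccc(Cl)cc4)C3)c2)no1` differs from compound 2 in one place: 5-methyl-1,2,4-oxadiazol-3-yl in place of methyl on an aromatic carbon. Within the data shown here, no measured step exchanges methyl for a five-membered aromatic ring, so the only guide is the step between compounds 1 and 3, which was within the scatter, and the fact that every compound measured so far sits at the same floor. An exchange of one aromatic substituent for another is therefore expected to bring no step beyond the scatter, in either direction.

Compound 4 is expected to give 0%, with a range from -5% to 10%. The expected step, no change at the digits printed from compound 2 to compound 4 (within the scatter), is none beyond the scatter.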

Compound 4, a percentage reported as inhibition, at one concentration (the size of the read-out at that concentration, not a potency): 0%
The estimate for compound 4 equals the measured number at the digits printed; the range from low to high includes it.
By their numbers in this assay, from the lowest: compounds 1, 2, 3 and 4 (each within the scatter of the next).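

In this assay, the step of no change at the digits printed from compound 2 to compound 4 (within the scatter) shows that this position, on an aromatic carbon meta to a large group, can carry a much bigger group with no inhibition appearing: methyl, with 1 heavy atom, gives way to 5-methyl-1,2,4-oxadiazol-3-yl, with 6 heavy atoms and 3 hydrogen-bond acceptors. Within the data shown here, the earlier compounds held no step at this position, so this is the first reading of it. No accompanying measurement bears on this result, so nothing can be said about what lies behind it.

From the compounds shown here alone, whether an amine or a carboxylic acid at this position would give any inhibition remains open. With every compound shown reading no inhibition, a change that would lower the read-out could not be seen here, so only a change that raises it would be informative.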